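This account rests on a few compounds, and the source may have more. Where it says the series, first, only, none or still open, it means among the compounds named here.

Measured so far:
- compound 1, `CCCNC(c1ccc(/C=C/C#N)cc1)c1ccnc(Nc2ccc(C#N)cc2)n1`: in an ADME assay on MT4 cells (Homo sapiens) for cytotoxicity, read by MTT assay, with a stated time of 5 days (a lower number here means that less compound is tolerated, a higher number that more compound is tolerated), compound 1 gives 34000 nM
- compound 2, `CC(C)NC(c1ccc(/C=C/C#N)cc1)c1ccnc(Nc2ccc(C#N)cc2)n1`: in this assay compound 2 gives 32300 nM

On these two numbers compound 2 and compound 1 cannot be told apart, since the step of a 1.1-fold lower number from compound 1 to compound 2 (0.02 log units; within the scatter) lies within the scatter of repeated measurements. Compound 3, `N#C/C=C/c1ccc(C(NO)c2ccnc(Nc3ccc(C#N)cc3)n2)cc1`, is not yet measured. It differs from compound 2 in one place: hydroxy in place of isopropyl on an amine nitrogen. Among the compounds with values here, the only measured step, from propyl to isopropyl, swaps one small carbon chain for another and left the number unchanged within scatter; no measured step exchanges a carbon chain for a hydroxy group on that amine nitrogen. With nothing to point either way, the step of a 1.2-fold lower number from compound 2 to compound 3 (0.06 log units; within the scatter) is expected to be small, with a wide range. For compound 3 the estimated value in this assay is 28000 nM, expected between 9000 nM and 90000 nM.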

Compound 3, half-maximal cytotoxic concentration: 161000 nM
The estimate for compound 3 lay 5.8-fold (0.76 log units) below the measured number, and the stated range ends below it.
By their numbers in this assay, from the lowest: compounds 2 and 1 (each within the scatter of the next); then compound 3.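

In this assay the amine nitrogen turns out to be a place where a change can shift the number: hydroxy in place of isopropyl gives a 5.0-fold higher number from compound 2 to compound 3 (0.70 log units; beyond the scatter) and hydroxy in place of propyl gives a 4.7-fold higher number from compound 1 to compound 3 (0.68 log units; beyond the scatter) with both steps beyond the scatter, so more compound is tolerated. The earlier swap between two small carbon chains showed no such shift, whereas here a carbon chain leaves and a hydroxy group enters, bringing a hydrogen-bond donor and acceptor with it. No measurement shown here accounts for this rise.

The compounds shown cannot separate the arrival of the hydroxy group from the loss of the carbon chain, since none carries a methoxy group or a plain unsubstituted amine at this place. On these data alone, how a longer chain or a ring on this nitrogen would behave also remains open.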